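This account rests on a few compounds, and the source may have more. Where it says the series, first, only, none or still open, it means among the compounds named here.

Among the compounds with values here, both compounds measured so far share one core and differ in the group on an aromatic nitrogen. In a functional assay on cells (Platelet, Homo sapiens) for inhibition (on this read-out higher numbers stand for weaker inhibition and lower numbers for stronger inhibition), compound 1 `CCOC(=O)c1ccc(-c2nn(Cc3ccccc3Cl)c3ccccc23)cc1` gives > 10000 nM, which is a limit and not a number. Compound 2 `CCOC(=O)c1ccc(-c2nn(-c3ccco3)c3ccccc23)cc1`, with furan-2-yl in that place, gives > 10000 nM, again a limit. The record so far is therefore (the limit of > 10000 nM in this assay, at which 2 of the 2 values shown sit), and no actual potency has been read for either compound.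

Compound 3 `CCOC(=O)c1ccc(-c2nn(-c3ccoc3)c3ccccc23)cc1` has furan-3-yl in place of furan-2-yl on that aromatic nitrogen, and the counted difference is furan-3-yl in place of furan-2-yl on an aromatic nitrogen. Within the data shown here, the only measured step at this place is a step that the two limits leave unreadable from compound 1 to compound 2, so it offers no size to carry over, even though it swaps a different group at the same place. The expectation therefore rests on compound 2, whose > 10000 nM is a limit, and on a change that keeps the same atoms. In this assay, no clear gain in inhibition is expected, and the estimated move is a step that the limit leaves unreadable from compound 2 to compound 3. For compound 3 the estimate is 14000 nM, with an expected range from 4000 nM to 40000 nM.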

Compound 3, half-maximal inhibitory concentration: > 10000 nM
Compound 3 ended at the assay's limit; the forecaster's own chance of this, stated with the estimate: 85%; the middle value is on the limit's open side.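

Compound 1, compound 2 and compound 3 all end at a limit and not at a number, so no step between them can be read: the limit of > 10000 nM in this assay, at which 3 of the 3 values shown sit.

The compounds shown leave open whether any group on that aromatic nitrogen of the shared core would give an actual potency value in this assay.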